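Isobutyryl to butyryl at the acyl end of the linked-ether series

A few compounds are considered here, and "the series" means these few. Any claim that something is new, unique, unknown or untested is made for them only; others in the source may bear on it.

Measured so far:
Compound 1, `Cc1cc(C(=O)O)ccc1OCCCCOc1ccc(C(=O)CC(C)C)c(O)c1C`, gives 192 nM in an assay on HEK293 cells for positive allosteric modulation of metabotropic glutamate receptor 2 (Rattus norvegicus), read by thallium flux, with a stated time of 2.5 min; on this read-out higher numbers stand for an effect only at larger amounts of compound and lower numbers for an effect already at smaller amounts.
Compound 2, `CCC(=O)c1ccc(OCCCCOc2cc(C(=O)O)ccc2OC)c(C)c1O`, gives 162 nM in this assay.
Compound 3, `CCCC(=O)c1ccc(OCCCCOc2cc(C(=O)O)ccc2OC)c(C)c1O`, gives 103 nM in this assay.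

Compounds 1, 2 and 3 all fall close together in this assay; compound 1 has the highest of the three numbers, but its distance to compound 2 and to compound 3 is within the scatter. Compound 3 and compound 2 differ in one place, (hydrogen in place of methyl on a saturated chain carbon, two bonds along the chain from a carbonyl carbon), and that step reads a 1.6-fold higher number from compound 3 to compound 2 (0.20 log units; within the scatter).

Compound 4, `CCCC(=O)c1ccc(OCCCCOc2ccc(C(=O)O)cc2C)c(C)c1O`, is not yet measured. It differs from compound 1 by hydrogen in place of methyl on a saturated chain carbon bound to two saturated chain carbons. Among the measured compounds shown here, this is the same kind of change as the one from compound 3 to compound 2, but not the same: there the leaving methyl sits on a saturated chain carbon two bonds along the chain from a carbonyl carbon, here on a saturated chain carbon bound to two saturated chain carbons. The difference between the core of compound 1 and the core of compound 3 is not broken down here.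

Given that the one measured step of this kind, a 1.6-fold higher number from compound 3 to compound 2 (0.20 log units; within the scatter), stayed within the scatter, the step from compound 1 to compound 4 is expected to be small as well, a 1.4-fold higher number from compound 1 to compound 4 (0.13 log units; within the scatter). Compound 4 is therefore estimated at 260 nM in this assay, with a likely range from 120 nM to 600 nM.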

Compound 4, half-maximal effective concentration: 104 nM
Compound 4: middle estimate off by 2.5-fold (0.40 log units), on the high side; measured number outside the range, below it.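

In this assay, hydrogen in place of methyl on a saturated chain carbon bound to two saturated chain carbons gives a 1.8-fold lower number from compound 1 to compound 4 (0.27 log units; within the scatter), so on the core of compound 1 this change on its own stays inside the noise of the measurement. Taken singly, neither step of this kind lies beyond the scatter, yet the two do not agree with each other, so the result of the change on one core cannot simply be carried over to the other: the same change on two cores in this assay, a 1.6-fold higher number (0.20 log units; within the scatter) from compound 3 to compound 2 and a 1.8-fold lower number (0.27 log units; within the scatter) from compound 1 to compound 4, 2.9-fold (0.46 log units) apart, beyond the scatter of two such steps

This does not show a rule for either core, since each core contributes a single pair and the leaving methyl sits at a different place in each pair, which leaves the effect of the core and the effect of the place inseparable here.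

The compounds shown leave open how the isobutylcarbonyl and propylcarbonyl groups would read on the core of compound 2 and compound 3, which would hold the place of the change fixed while the core varies. Also open, from the compounds shown here alone, is how a longer acyl chain, a cyclopropylcarbonyl group, or an amide in place of the carboxylic acid would read on either core.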